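The source may report more compounds than this note shows. Statements on the series, on what has been measured and on what is new or still open speak of the compounds shown alone.

Measured in a functional assay on MKN-45 cells (Homo sapiens) for cytotoxicity, read by MTT assay, with a stated time of 72 h; a lower number here means a stronger inhibitor, a higher number a weaker inhibitor:
compound 1, `CN(C)CCn1cnnc1-c1cc(Oc2ccc(NC(=O)N/N=C/c3c(O)ccc4ccccc34)cc2F)ccn1`: 2020 nM
compound 2, `CN(C)CCn1cnnc1-c1cc(Oc2ccc(NC(=O)N/N=C/c3cccc(Br)c3)cc2F)ccn1`: 450 nM
compound 3, `CN(C)CCn1cnnc1-c1cc(Oc2ccc(NC(=O)N/N=C/c3cc(Br)c(O)c(Br)c3)cc2F)ccn1`: 4320 nM

Compound 3 gives the highest number of the three in this assay; compound 1 stands nearest and compound 2 furthest, as the steps of a 2.1-fold higher number from compound 1 to compound 3 (0.33 log units; beyond the scatter) and a 9.6-fold higher number from compound 2 to compound 3 (0.98 log units; beyond the scatter) show. Compound 4, `CN(C)CCn1cnnc1-c1cc(Oc2ccc(NC(=O)N/N=C/c3ccc(F)cc3Cl)cc2F)ccn1`, is not yet measured. It differs from compound 3 in one place: 2-chloro-4-fluorophenyl in place of 3,5-dibromo-4-hydroxyphenyl on a carbon with a double bond to nitrogen.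

The step that bears most directly on this change is a 9.6-fold higher number from compound 2 to compound 3 (0.98 log units; beyond the scatter), where a phenyl carrying only a bromine was exchanged for the 3,5-dibromo-4-hydroxyphenyl. The change to compound 4 runs the other way: the hydroxyl group leaves and a phenyl carrying only halogens enters, though the halogens differ from those in compound 2. The step of a 4.5-fold lower number from compound 1 to compound 2 (0.65 log units; beyond the scatter) points the same way, a hydroxyl-bearing group giving the higher number there as well. Among the measured compounds shown here, no measured step tests a chloro-fluoro pattern, so the size is uncertain, but a downward step beyond the scatter is expected, somewhat smaller than the one from the dibromo-hydroxy exchange.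

Compound 4 is therefore expected to give about 700 nM in this assay, within 250 nM to 2000 nM, an estimated step of a 6.2-fold lower number from compound 3 to compound 4 (0.79 log units; beyond the scatter).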

Compound 4, half-maximal inhibitory concentration: 870 nM
Compound 4: middle estimate off by 1.2-fold (0.09 log units), on the low side, within the range that was stated.
By their numbers in this assay, from the lowest: compounds 2 and 4 (each within the scatter of the next); then compound 1; then compound 3.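

In this assay, a second phenyl carrying only halogens now stands on the carbon with a double bond to nitrogen, and the step of a 1.9-fold higher number from compound 2 to compound 4 (0.29 log units; within the scatter) does not separate 2-chloro-4-fluorophenyl from 3-bromophenyl, although the two groups differ in which halogens they carry. Both hydroxyl-bearing groups now sit on the higher side of this new group, with the steps of a 5.0-fold lower number from compound 3 to compound 4 (0.70 log units; beyond the scatter) and a 2.3-fold lower number from compound 1 to compound 4 (0.37 log units; beyond the scatter), so across these four compounds the halogen-only phenyl groups give lower numbers than the hydroxyl-bearing groups, and none of the four goes against this. No measurement offered here explains the gap between the halogen-only and the hydroxyl-bearing groups.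

Whether the hydroxyl itself or the rest of each group accounts for that gap stays open: every pair shown changes more than the hydroxyl alone, and the bromines of the 3,5-dibromo-4-hydroxyphenyl and the fused ring of the 2-hydroxynaphthalen-1-yl change with it. Also open, from the compounds shown here alone, is where an unsubstituted phenyl, or a phenyl carrying a methoxy, an amine or a carboxylic acid, would fall at this position.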